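Bromo for trifluoromethyl on a weakly cytotoxic tosylate

The source may report more compounds than this note shows. Statements on the series, on what has been measured and on what is new or still open speak of the compounds shown alone.

The study measures growth inhibition of a lung-derived cell line in a functional assay on A549 cells (Homo sapiens) for cytotoxicity, read by MTT assay, with a stated time of 4 days; a higher number here means a weaker inhibitor, a lower number a stronger inhibitor. Compound 1 `C=C1C[C@]23C[C@@]1(O)CC[C@H]2c1cc(Br)c(O)c(C)c1[C@@H]3Cn1cc(-c2ccc(Cl)cc2)nn1` gives 10500 nM in this assay. Compound 2 `Cc1ccc(S(=O)(=O)Oc2ccc3c(c2C)[C@H](Cn2cc(-c4ccc(C(F)(F)F)cc4)nn2)[C@@]24CC(=O)[C@@](C)(CC[C@@H]32)C4)cc1` gives only a limit in this assay, > 20000 nM. Compound 3 `C=C1C[C@]23C[C@@]1(O)CC[C@H]2c1ccc(O)c(C)c1[C@@H]3Cn1cc(-c2ccccn2)nn1` also reaches only a limit in this assay, > 20000 nM. Compound 2 thus stands at the weak end of the numbers shown, and it is not alone there, because of the limit of > 20000 nM in this assay, at which 2 of the 3 values shown sit.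

The step from compound 2 leads to compound 4 `Cc1ccc(S(=O)(=O)Oc2ccc3c(c2C)[C@H](Cn2cc(-c4ccc(Br)cc4)nn2)[C@@]24CC(=O)[C@@](C)(CC[C@@H]32)C4)cc1`, which is not yet measured. The change is bromo in place of trifluoromethyl on an aromatic carbon. Both are small, uncharged substituents with no hydrogen-bond donor or acceptor at the same place on the aryl group attached to the triazole. Among the compounds with values here, with no step between measured compounds on record, no direction can be read from the data; the step in this assay is expected to be none beyond the scatter. The step from compound 2 to compound 4 is estimated at a step that the limit leaves unreadable from compound 2 to compound 4. Compound 4 is therefore expected to give about 25000 nM in this assay, in the range 8000 nM to 80000 nM, most likely again as a limit.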

Compound 4, half-maximal inhibitory concentration: > 20000 nM
Compound 4: a limit, no number (the forecaster's own chance of this, stated with the estimate: 70%); the middle value lies beyond the limit too.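

Compound 4 gives > 20000 nM in this assay and this is only a limit. Within the data shown here, compound 2 also stands only at a limit, so no step between compound 2 and compound 4 can be read. The compounds shown leave open whether 4-(trifluoromethyl)phenyl and 4-bromophenyl differ at all in this assay on the shared core.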